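The compounds below may be only part of what the source reports. "The series", "measured", "known", "first", "only" and "open" are said of these compounds alone.

Measured so far:
- compound 1, `CC(C)(CC(=O)N[C@@H]1CCc2ccccc2N(Cc2ccc(-c3ccccc3-c3nn[nH]n3)cc2)C1=O)NCCO`: 30 nM
- compound 2, `C[C@@H](O)CCNC(C)(C)CC(=O)N[C@@H]1CCc2ccccc2N(Cc2ccc(-c3ccccc3-c3nn[nH]n3)cc2)C1=O`: 10 nM
- compound 3, `C[C@H](O)CNC(C)(C)C(=O)N[C@@H]1CCc2ccccc2N(Cc2ccc(-c3ccccc3-c3nn[nH]n3)cc2)C1=O`: 700 nM

In a functional assay (Pituitary gland cell) with Rattus norvegicus as the target (on this read-out higher numbers stand for an effect only at larger amounts of compound and lower numbers for an effect already at smaller amounts), compound 3 stands with the highest number of the three; the step of a 23-fold higher number from compound 1 to compound 3 (1.37 log units; beyond the scatter) and the step of a 70-fold higher number from compound 2 to compound 3 (1.85 log units; beyond the scatter) both run beyond the scatter, so compound 3 is the weakest of the measured set. Compound 4, `CCCNC(C)(C)CC(=O)N[C@@H]1CCc2ccccc2N(Cc2ccc(-c3ccccc3-c3nn[nH]n3)cc2)C1=O`, has not been measured. It differs from compound 3 by 2-methyl-2-(propylamino)propyl in place of 1-((2-hydroxypropyl)amino)-1-methylethyl on a carbonyl carbon; the entering group carries the same chain length as the corresponding groups of compound 1 and compound 2, but lacks the hydroxy that both of those carry. Among the measured compounds shown here, the steps that bear on this are a 23-fold higher number from compound 1 to compound 3 (1.37 log units; beyond the scatter) and a 70-fold higher number from compound 2 to compound 3 (1.85 log units; beyond the scatter), both large and both tied to the shortening of the chain; the step of a 3.0-fold lower number from compound 1 to compound 2 (0.48 log units; beyond the scatter) is modest. Compound 4 is therefore expected to move back toward compound 1 and compound 2 in this assay, though with the hydroxy gone the return is expected to be incomplete, giving an estimated step of a 12-fold lower number from compound 3 to compound 4 (1.07 log units; beyond the scatter). The estimate for compound 4 is 60 nM, within 15 nM to 250 nM.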

Compound 4, concentration for half-maximal effect: 50 nM
Estimate against measurement, compound 4: 1.2-fold (0.08 log units) above; the measured number falls inside the stated range.
By their numbers in this assay, from the lowest: compound 2; then compounds 1 and 4 (each within the scatter of the next); then compound 3.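

In this assay, a 14-fold lower number from compound 3 to compound 4 (1.15 log units; beyond the scatter) shows that 2-methyl-2-(propylamino)propyl on this carbonyl carbon regains most of the ground lost with compound 3, and it does so with no hydroxy at all. Methyl in place of hydroxy on the saturated chain carbon gives a 1.7-fold higher number from compound 1 to compound 4 (0.22 log units; within the scatter), so compound 1 and compound 4 cannot be told apart and the hydroxy of compound 1 shows no effect on this read-out. Methyl in place of 1-hydroxyethyl gives a 5.0-fold higher number from compound 2 to compound 4 (0.70 log units; beyond the scatter), a modest step, so the group of compound 2 is the only one here that stands apart from that of compound 4.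

Nothing at hand explains these steps. As far as these compounds go, it remains open whether a butyl chain would match compound 2 without any hydroxy, and whether a terminal amine or carboxylic acid would be tolerated at the chain end.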